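The source may hold more compounds than are shown below. What is called first, only, known or untested is meant among the compounds shown, and "the series" means these compounds.

In a functional assay on the whole organism with Mus musculus as the target, in the rotarod test (a higher number here means that more compound is needed for the effect, a lower number that less compound is needed), compound 1 `Cc1cccc2c1CC/C2=C\C(=O)NC1CC1` gives 64 mg/kg, compound 2 `NC(=O)/C=C1\CCc2c1ccc(F)c2F` gives 50 mg/kg and compound 3 `O=C(/C=C1\CCc2ccc(F)cc21)NC1CC1` gives 62 mg/kg. These three numbers lie within the scatter of one another, so compound 1 stands level with both. Compound 4 `O=C(/C=C1\CCc2c(Cl)cccc21)NC1CC1` has chloro in place of methyl on an aromatic carbon of the core of compound 1 (chloro in place of methyl on an aromatic carbon). Going by the values given here, no pair of measured compounds differs in one place only. Compound 3 at 62 mg/kg and compound 1 at 64 mg/kg differ in their aromatic substituent yet stay within the scatter, so no shift beyond the scatter is expected here, in either direction. The expected step is a 1.1-fold lower number from compound 1 to compound 4 (0.03 log units; within the scatter). For compound 4 the estimated value is 60 mg/kg, with an expected range of 35 mg/kg to 105 mg/kg.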

Compound 4, dose for half-maximal effect: 66 mg/kg
Compound 4: the middle estimate sits 1.1-fold (0.04 log units) below what was measured; the measured number falls inside the stated range.
By their numbers in this assay, from the lowest: compounds 2, 3, 1 and 4 (each within the scatter of the next).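

In this assay, going by these compounds alone, chloro in place of methyl on this aromatic carbon gives a 1.0-fold higher number from compound 1 to compound 4 (0.01 log units; within the scatter) and is the first change in one place only. At this position of the shared core, the two groups can be exchanged without a shift beyond the scatter. No measurement of any property bears on this result.

On these data alone, whether an amine, a carboxylic acid or a methoxy group at this position would move the number remains open. Also open, as far as these compounds go, is whether a longer chain in place of the cyclopropyl group on the amide would do so.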